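Acetamido to methylcarbamoyl: expected agonist potency

The compounds below may be only part of what the source reports. "The series", "measured", "known", "first", "only" and "open" are said of these compounds alone.

Measured so far:
compound 1 `CNc1nc(NCc2ccc(S(C)(=O)=O)cc2)cc(-c2ccccn2)n1`: 36 nM
compound 2 `CNc1nc(NCc2ccc(Cl)cc2)cc(-c2ccccn2)n1`: 15 nM
compound 3 `CNc1nc(NCc2ccc(NC(C)=O)cc2)cc(-c2ccccn2)n1`: 5 nM

In a functional assay on HEK293 cells for agonist activity at G-protein coupled receptor 39 (Homo sapiens), read by inositol phosphate accumulation (on this read-out lower numbers stand for an effect already at smaller amounts and higher numbers for an effect only at larger amounts of compound), compound 3 gives the lowest number of the three. The steps of a 7.2-fold lower number from compound 1 to compound 3 (0.86 log units; beyond the scatter) and a 3.0-fold lower number from compound 2 to compound 3 (0.48 log units; beyond the scatter) both lie beyond the scatter, as does a 2.4-fold lower number from compound 1 to compound 2 (0.38 log units; beyond the scatter). Compound 4 `CNC(=O)c1ccc(CNc2cc(-c3ccccn3)nc(NC)n2)cc1` differs from compound 3 by methylcarbamoyl in place of acetamido on an aromatic carbon. For the measured compounds named here, no measured step covers this change directly; the three steps show only that exchanging the group at this position shifts the read-out modestly, with acetamido giving the lowest number so far. With the same atoms joined differently, a small step is expected, a 1.6-fold higher number from compound 3 to compound 4 (0.20 log units; within the scatter), more likely toward a somewhat higher number than a lower one. Compound 4 is therefore estimated at 8 nM, with a range from 3 nM to 25 nM.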

Compound 4, half-maximal effective concentration: 30 nM
Beside the measured number, compound 4's estimate is 3.8-fold (0.57 log units) below it; the whole stated range lies below it.
By their numbers in this assay, from the lowest: compound 3; then compounds 2, 4 and 1 (each within the scatter of the next, the first and the last beyond it).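

In this assay, swapping acetamido for methylcarbamoyl at this position is not a neutral exchange, even with the same atoms joined differently: there is a 6.0-fold higher number from compound 3 to compound 4 (0.78 log units; beyond the scatter) in the series. Methylcarbamoyl shows no separation from the other two groups, with a 2.0-fold higher number from compound 2 to compound 4 (0.30 log units; within the scatter) and a 1.2-fold lower number from compound 1 to compound 4 (0.08 log units; within the scatter) as the steps, and this leaves acetamido alone at the low end. No evidence at hand accounts for the gap between the two arrangements. Still open, from the compounds shown here alone, is whether a plain amine, or propionamido with its longer chain, at this position would stay near compound 3 or move toward compound 4.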